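Ester groups on the nitrogen: the step to compound 4

The source may hold more compounds than are shown below. What is called first, only, known or untested is meant among the compounds shown, and "the series" means these compounds.

In a functional assay on DU-145 cells (Homo sapiens) for cytotoxicity, read by trypan blue exclusion, with a stated time of 96 h (a lower number here means a stronger inhibitor, a higher number a weaker inhibitor), three compounds share one core and differ only in the ester-bearing group on a nitrogen on an aromatic ring. Compound 1 `COC(=O)CNc1cc(CS(=O)(=O)/C=C/c2c(OC)cc(OC)cc2OC)ccc1OC` gives 100 nM, compound 2 `COC(=O)C(F)(F)Nc1cc(CS(=O)(=O)/C=C/c2c(OC)cc(OC)cc2OC)ccc1OC` gives 250 nM, and compound 3 `COC(=O)C(C)(C)Nc1cc(CS(=O)(=O)/C=C/c2c(OC)cc(OC)cc2OC)ccc1OC` gives 2500 nM, the highest number and so the weakest of the three.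

Compound 4 `COC(=O)C(Nc1cc(CS(=O)(=O)/C=C/c2c(OC)cc(OC)cc2OC)ccc1OC)c1ccccc1` is still unmeasured. The change to it is methoxycarbonyl)(benzyl in place of 1-(methoxycarbonyl)-1-methylethyl on a nitrogen on an aromatic ring: methoxycarbonyl)(benzyl in place of 1-(methoxycarbonyl)-1-methylethyl, on a nitrogen on an aromatic ring.

Two measured steps end at the same group that leaves here: a 25-fold higher number from compound 1 to compound 3 (1.40 log units; beyond the scatter), which is large, and a 10-fold higher number from compound 2 to compound 3 (1.00 log units; beyond the scatter), which is modest. For the measured compounds named here, no measured compound carries the entering aromatic ring, so these steps guide the estimate only loosely. With compound 3 at the top of the measured range, a modest move towards a lower number is expected, with wide uncertainty. The expected change is a 3.1-fold lower number from compound 3 to compound 4 (0.49 log units; beyond the scatter). The estimate for compound 4 is 800 nM, with an expected range from 150 nM to 4000 nM.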

Compound 4, half-maximal inhibitory concentration: 75 nM
The estimate for compound 4 lay 11-fold (1.03 log units) above the measured number; the whole stated range lies above it.
By their numbers in this assay, from the lowest: compounds 4 and 1 (each within the scatter of the next); then compound 2; then compound 3.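

In this assay, a substituent on the saturated chain carbon bound to a carbonyl carbon and a nitrogen on an aromatic ring need not cost activity: with phenyl in place of hydrogen there, the step is a 1.3-fold lower number from compound 1 to compound 4 (0.12 log units; within the scatter). The loss seen with 1-(methoxycarbonyl)-1-methylethyl is thus not a general price of substitution on this carbon, since methoxycarbonyl)(benzyl, which has more heavy atoms, gives a 33-fold lower number from compound 3 to compound 4 (1.52 log units; beyond the scatter), and in place of difluoro(methoxycarbonyl)methyl gives a 3.3-fold lower number from compound 2 to compound 4 (0.52 log units; beyond the scatter). Nothing available explains the difference between these groups.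

Still open, from the compounds shown here alone, is whether a single methyl or a substituted phenyl on this carbon would behave like the phenyl of compound 4. Also open, going by these compounds, is whether the methyl ester can give way to a carboxylic acid or an amide.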